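Methoxy for fluoro on the benzothiazole amide partner

The source may hold more compounds than are shown below. What is called first, only, known or untested is meant among the compounds shown, and "the series" means these compounds.

Three amides share one core. In a functional assay on MCF7 cells (Homo sapiens) for cytotoxicity, read by MTT assay, with a stated time of 48 h (a lower number here means a stronger inhibitor, a higher number a weaker inhibitor), compound 1 `COc1ccc(-c2cc(C(=O)Nc3nc4ccc(F)cc4s3)nc3cc(-c4ccccc4)nn23)cc1` gives 35500 nM; compound 2 `COc1ccc(-c2cc(C(=O)Nc3nc4ccc(F)cc4s3)nc3cc(-c4ccccc4)nn23)cc1OC` gives 22400 nM; compound 3 `COc1cc(-c2cc(C(=O)Nc3nc4ccc(F)cc4s3)nc3cc(-c4ccccc4)nn23)cc(OC)c1OC` gives 27500 nM. Compound 3 stands second highest of the three, with every gap within the scatter: a 1.3-fold lower number from compound 1 to compound 3 (0.11 log units; within the scatter) and a 1.2-fold higher number from compound 2 to compound 3 (0.09 log units; within the scatter), as was a 1.6-fold lower number from compound 1 to compound 2 (0.20 log units; within the scatter). Compound 4 `COc1ccc2nc(NC(=O)c3cc(-c4cc(OC)c(OC)c(OC)c4)n4nc(-c5ccccc5)cc4n3)sc2c1` differs from compound 3 by methoxy in place of fluoro on an aromatic carbon. Among the compounds with values here, no measured step touches that ring; the three steps seen all concern methoxy groups on the other aryl ring and none left the scatter. Nothing therefore supports a step beyond the scatter in this assay, and compound 4 is expected near compound 3, a 1.0-fold lower number from compound 3 to compound 4 (0.01 log units; within the scatter). The estimate for compound 4 is 27000 nM, range 9000 nM to 80000 nM.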

Compound 4, half-maximal inhibitory concentration: 2950 nM
The estimate for compound 4 lay 9.2-fold (0.96 log units) above the measured number; measured number below the stated range.
By their numbers in this assay, from the lowest: compound 4; then compounds 2, 3 and 1 (each within the scatter of the next).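

Within the data shown here, the 6-fluoro-1,3-benzothiazol-2-yl to 6-methoxy-1,3-benzothiazol-2-yl change is the only single change that leaves the scatter in this assay, with a 9.3-fold lower number from compound 3 to compound 4 (0.97 log units; beyond the scatter). The methoxy changes on the other aryl ring all stayed within it, so the amide partner is the more responsive site among these compounds. No available evidence bears on the reason for this step.

As far as these compounds go, the step rests on one pair carrying 3,4,5-trimethoxyphenyl, so it remains open whether the same change gives a similar step alongside 4-methoxyphenyl. Also open, from the compounds shown here alone, is how an amine, a hydroxyl or a longer alkoxy chain at this position would compare with methoxy.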